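Returning an amino group to the sulfonyl sulfur

The source may hold more compounds than are shown below. What is called first, only, known or untested is meant among the compounds shown, and "the series" means these compounds.

Within the data shown here, in a functional assay on BXPC-3 cells (Homo sapiens) for inhibition, read by MTT assay, with a stated time of 7 days (on this read-out higher numbers stand for weaker inhibition and lower numbers for stronger inhibition), compound 3 `CCC(CC)S(=O)(=O)c1ccc(S(=O)(=O)N2CCC[C@@H](C(=O)N3CCN(c4nc(C(C)C)no4)CC3)C2)cc1` gives 120 nM, the lowest of the three numbers measured so far. Compound 1 `CCOC(=O)[C@@H]1CCCN(S(=O)(=O)c2ccc(S(=N)(=O)N(CC)CC)cc2)C1` gives 3600 nM, and compound 2 `CC(C)c1noc(N2CCN(C(=O)[C@@H]3CCCN(S(=O)(=O)c4ccc(S(=O)(=O)NC5CC5)cc4)C3)CC2)n1` gives 6700 nM, the highest of the three. Compound 4 `CC(C)c1noc(N2CCN(C(=O)[C@@H]3CCCN(S(=O)(=O)c4ccc(S(=O)(=O)NC(C)(C)C)cc4)C3)CC2)n1` has not yet been measured in this assay. Its structure differs from that of compound 3 in one place only: (tert-butyl)amino in place of pentan-3-yl on a sulfonyl sulfur.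

Among the measured compounds shown here, only one measured step speaks to this change, and it runs in the opposite direction. From compound 2 to compound 3 a cyclopropylamino group on the sulfonyl sulfur was replaced by pentan-3-yl, and the number fell sharply, a 56-fold lower number from compound 2 to compound 3 (1.75 log units; beyond the scatter). Compound 4 now puts an amino group back on that sulfonyl sulfur, with a tert-butyl group on its nitrogen rather than a cyclopropyl. Since the move away from an amino group gave a large drop, the move back is expected to give a large rise, and the expected step is a 21-fold higher number from compound 3 to compound 4 (1.32 log units; beyond the scatter). The tert-butyl and cyclopropyl groups are not the same, however, so the size of this rise is uncertain. For compound 4 in this assay the estimated value is 2500 nM, with a likely range from 600 nM to 9000 nM.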

Compound 4, half-maximal inhibitory concentration: 2600 nM
For compound 4 the middle estimate is 1.0-fold (0.02 log units) below the measured one; the range from low to high includes it.
By their numbers in this assay, from the lowest: compound 3; then compounds 4, 1 and 2 (each within the scatter of the next, the first and the last beyond it).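

In this assay, the swap on the sulfonyl sulfur gives a 22-fold higher number from compound 3 to compound 4 (1.34 log units; beyond the scatter), although pentan-3-yl and (tert-butyl)amino have the same count of heavy atoms, and neither contains a ring. The change therefore amounts to one carbon exchanged for one nitrogen, which brings in one hydrogen-bond donor, and this shows that the large step needs no change in heavy-atom count or loss of a ring. Between the two amino groups, tert-butyl in place of cyclopropyl on the sulfonamide nitrogen gives only a 2.6-fold lower number from compound 2 to compound 4 (0.41 log units; beyond the scatter), so among these four compounds the choice of group on that nitrogen counts for less than the exchange of pentan-3-yl for either amino group.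

Nothing shown here gives a measured reason for these differences. Still open, going by these compounds, is whether a cyclopentyl or tert-butyl group attached directly to the sulfonyl sulfur would stay near compound 3, and whether a (tert-butyl)(methyl)amino group, which has no hydrogen on its nitrogen, would stay near compound 4 or move towards compound 3.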